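The source may hold more compounds than are shown below. What is called first, only, known or untested is meant among the compounds shown, and "the series" means these compounds.

Measured so far:
- compound 1, `CC[C@@H](C)[C@H](NC(=O)c1ccc(C(CC)(CC)c2ccc(OCC(=O)C(C)(C)C)c(C)c2)n1CC)C(=O)OC`: 590 nM
- compound 2, `C=CCN(C)C(=O)c1ccc(C(CC)(CC)c2ccc(OCC(O)C(C)(C)C)c(C)c2)n1CC`: 3950 nM

Both were tested in an assay on HL-60 cells for agonist activity at vitamin D3 receptor (Homo sapiens), read by microscopy, with a stated time of 96 h; a higher number here means that more compound is needed for the effect, a lower number that less compound is needed. Of the two, compound 1 has the lower number, and compound 2 the higher one; the gap between them is wider than the usual scatter. Compound 3, `CC[C@@H](C)[C@H](NC(=O)c1ccc(C(CC)(CC)c2ccc(OCC(=O)C(C)(C)C)c(C)c2)n1CC)C(=O)O`, has not yet been measured. It differs from compound 1 in a single place: hydrogen in place of methyl on an oxygen next to a carbonyl group. The core, the pendant groups on it and the chain bearing the amide are all kept; only the ester end is opened to the free acid.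

Within the data shown here, no pair of measured compounds here shows this same change, so its effect cannot be read off directly. The expectation is that the number for compound 3 in this assay moves somewhat upward from compound 1, by a 2.0-fold higher number from compound 1 to compound 3 (0.31 log units; beyond the scatter), though a result within the scatter would not be surprising. For compound 3 the estimated value in this assay is 1200 nM, with a likely range from 300 nM to 5000 nM.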

Compound 3, half-maximal effective concentration: 10 nM
The estimate for compound 3 lay 120-fold (2.08 log units) above the measured number, and the stated range ends above it.
By their numbers in this assay, from the lowest: compound 3; then compound 1; then compound 2.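

In this assay, the end of the chain bearing the amide proves highly sensitive: replacing methoxycarbonyl with carboxy gives a 59-fold lower number from compound 1 to compound 3 (1.77 log units; beyond the scatter), so much less compound is needed for the effect. Compound 1 and compound 2 differ in more than one place, whereas this pair shows that removing a single methyl from this oxygen can shift the number strongly while everything else stays the same. Nothing available here explains why the free acid gives so much lower a number.

On these data alone, it remains open whether this low number requires the carboxylic acid itself, or whether an ethyl ester, a primary amide or a tetrazole at the same end would give a similar result. As far as these compounds go, it is also open whether the same change would have a similar effect with a hydroxyl in place of the ketone on the other side of the molecule.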